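This account rests on a few compounds, and the source may have more. Where it says the series, first, only, none or still open, it means among the compounds named here.

Measured compounds in this series:
compound 3 `Cn1c(=O)n(C2OC(CO)[C@@H](O)[C@H]2O)c2nc(N)nc(O)c21` – 10 uM
compound 1 `COc1ccc(Cn2c(=O)n(C3OC(CO)[C@@H](O)[C@H]3O)c3nc(N)nc(O)c32)cc1` – 135 uM
compound 2 `CN(C)CCCn1c(=O)n(C2OC(CO)[C@@H](O)[C@H]2O)c2nc(N)nc(O)c21` – 194 uM

In a functional assay (B cells) with Mus musculus as the target (on this read-out lower numbers stand for an effect already at smaller amounts and higher numbers for an effect only at larger amounts of compound), compound 3 gives 10 uM, the lowest of the three numbers; compound 1 and compound 2 both stand beyond the scatter away from it. Compound 4 `CCCCn1c(=O)n(C2OC(CO)[C@@H](O)[C@H]2O)c2nc(N)nc(O)c21` differs from compound 3 by propyl in place of hydrogen on a saturated chain carbon bound to an aromatic nitrogen. Going by the values given here, two measured steps touch the same carbon: a 14-fold lower number from compound 1 to compound 3 (1.13 log units; beyond the scatter) and a 19-fold lower number from compound 2 to compound 3 (1.29 log units; beyond the scatter). Read in the other direction, each shows that replacing hydrogen on that carbon by 4-methoxyphenyl or by 2-(dimethylamino)ethyl raised the number by a large amount. Propyl is a third group entering at the same place; a rise is therefore expected, though its size is uncertain since propyl is neither of the two groups seen. Compound 4 is estimated at 45 uM, range 12 uM to 160 uM, an expected step of a 4.5-fold higher number from compound 3 to compound 4 (0.65 log units; beyond the scatter).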

Compound 4, concentration for half-maximal effect: 11 uM
Compound 4: the middle estimate sits 4.1-fold (0.61 log units) above what was measured; the measured number lies below the stated range.
By their numbers in this assay, from the lowest: compounds 3 and 4 (each within the scatter of the next); then compounds 1 and 2 (each within the scatter of the next).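

In this assay, propyl on a saturated chain carbon bound to an aromatic nitrogen gives a 1.1-fold higher number from compound 3 to compound 4 (0.04 log units; within the scatter), so a group at this place does not by itself raise the number. Against propyl, the 4-methoxyphenyl of compound 1 stands apart, with a 12-fold lower number from compound 1 to compound 4 (1.09 log units; beyond the scatter). Methyl in place of dimethylamino gives an 18-fold lower number from compound 2 to compound 4 (1.25 log units; beyond the scatter), which ties the high number of compound 2 to the dimethylamino group rather than to the chain. As far as these compounds go, whether a longer chain such as hexyl, or a chain ending in a carboxylic acid, stays level with propyl remains open. Nothing given here explains these steps.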